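The source may hold more compounds than are shown below. What is called first, only, known or untested is meant among the compounds shown, and "the series" means these compounds.

Compound 1, `CCOc1ccc(F)cc1C(C)NC(=O)NS(=O)(=O)c1ccc(C)cc1`, reaches only the limit of the assay in a functional assay on thoracic aorta (Rattus norvegicus, strain Wistar), with a stated time of 15 min (a higher number here means that more compound is needed for the effect, a lower number that less compound is needed), giving > 300000 nM.
Compound 2, `CCOc1ccc(F)cc1C(C)NC(=O)N(C)S(=O)(=O)c1ccc(C)cc1`, gives 7800 nM in this assay.
Compound 3, `CCOc1ccc(F)cc1C(C)NC(=O)N(C)S(=O)(=O)c1ccccc1`, gives 11500 nM in this assay.

Within the data shown here, of the two numbers, the one for compound 2 is the lower, but the gap to compound 3, a 1.5-fold higher number from compound 2 to compound 3 (0.17 log units; within the scatter), lies within the scatter, so the two cannot be told apart. Compound 1 stands apart at a limit, (the limit of > 300000 nM in this assay, at which 1 of the 3 values shown sits). The two measured steps differ greatly in size: an at least 38-fold lower number from compound 1 to compound 2 (1.58 log units; beyond the scatter) is large, whereas a 1.5-fold higher number from compound 2 to compound 3 (0.17 log units; within the scatter) is small.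

The unmeasured compound 4, `CCOc1ccc(Cl)cc1C(C)NC(=O)N(C)S(=O)(=O)c1ccc(C)cc1`, differs from compound 2 by chloro in place of fluoro on an aromatic carbon.

Neither measured step touches this halogen. Among the measured compounds shown here, the only step on an aromatic carbon, a 1.5-fold higher number from compound 2 to compound 3 (0.17 log units; within the scatter), is within the scatter, and it concerns a different ring. The large step, an at least 38-fold lower number from compound 1 to compound 2 (1.58 log units; beyond the scatter), concerns the nitrogen and so says nothing about this change. There is therefore no measured basis for expecting a step beyond the scatter in this assay in either direction. Compound 4 is expected to give about 7000 nM, within 3000 nM to 18000 nM. This estimate amounts to a step of a 1.1-fold lower number from compound 2 to compound 4 (0.05 log units; within the scatter), which is expected to stay within the scatter.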

Compound 4, half-maximal effective concentration: 12200 nM
Compound 4: middle estimate off by 1.7-fold (0.24 log units), on the low side; the measured number falls inside the stated range.
By their numbers in this assay, from the lowest: compounds 2, 3 and 4 (each within the scatter of the next). At a limit, above all of these: compound 1.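

Until compound 4, none of the compounds differed at the halogen para to an ethoxy group. In this assay the exchange of fluoro for chloro there comes to a 1.6-fold higher number from compound 2 to compound 4 (0.19 log units; within the scatter) and so leaves compound 2 and compound 4 indistinguishable, which shows that this position accepts either halogen without a change that can be read in this assay. Among these compounds, that step is far smaller than the one on the amide-type nitrogen, an at least 38-fold lower number from compound 1 to compound 2 (1.58 log units; beyond the scatter), so among the places varied so far, the nitrogen is the only one where a change goes beyond the scatter, while the halogen position joins the aromatic methyl position as one where none does. Nothing measured here bears on the cause of this result.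

The compounds shown carry only fluoro or chloro at this position, so it remains open whether bromo, trifluoromethyl, a nitrile or a hydroxyl group there would also stay within the scatter. From the compounds shown here alone, the exchange is also read only on the core of compound 2, and whether chloro behaves the same way on the core of compound 3 remains open.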